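The source may hold more compounds than are shown below. What is called first, only, known or untested is meant among the compounds shown, and "the series" means these compounds.

Compound 1 `O=C(/C=C/c1cn(-c2ccccc2)nc1-c1cccnc1)c1cc[nH]c1` and compound 2 `COc1cc(OC)c(C(=O)/C=C/c2cn(-c3ccccc3)nc2-c2cccnc2)c(OC)c1` share a ring that carries a pyridin-3-yl group; the difference between their two cores is not broken down here. In a functional assay on Huh-7 cells (Homo sapiens) for inhibition, read by sulforhodamine B assay, with a stated time of 72 h (a higher number here means a weaker inhibitor, a lower number a stronger inhibitor), compound 1 gives 3300 nM and compound 2 gives 500 nM. Compound 3 `O=C(/C=C/c1cn(-c2ccccc2)nc1-c1ccncc1)c1cc[nH]c1` differs from compound 1 by the change (pyridin-4-yl in place of pyridin-3-yl on an aromatic carbon); in this assay compound 3 gives 28800 nM, which is an 8.7-fold higher number from compound 1 to compound 3 (0.94 log units; beyond the scatter). Compound 4 `COc1cc(OC)c(C(=O)/C=C/c2cn(-c3ccccc3)nc2-c2ccncc2)c(OC)c1` differs from compound 2 by the change (pyridin-4-yl in place of pyridin-3-yl on an aromatic carbon), the same kind of change, though here the place is next to the ring atom that bears a large group rather than a group of 9 heavy atoms. Among the measured compounds shown here, for compound 4 the step is expected to be about an 8.0-fold higher number from compound 2 to compound 4 (0.90 log units; beyond the scatter), resting on the single earlier example, so the estimate for compound 4 is 4000 nM, plausibly between 1500 nM and 12000 nM.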

Compound 4, half-maximal inhibitory concentration: 2600 nM
Beside the measured number, compound 4's estimate is 1.5-fold (0.19 log units) above it, within the range that was stated.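

Putting pyridin-4-yl in place of pyridin-3-yl also weakens the compound on the second core: in this assay the step is a 5.2-fold higher number from compound 2 to compound 4 (0.72 log units; beyond the scatter). Set beside the first example, the change gives a similar result on both cores: the same change on two cores in this assay, an 8.7-fold higher number (0.94 log units; beyond the scatter) from compound 1 to compound 3 and a 5.2-fold higher number (0.72 log units; beyond the scatter) from compound 2 to compound 4, 1.7-fold (0.22 log units) apart, within the scatter of two such steps. For these two cores, the direction and rough size of the step carry over, but two pairs cannot show that this holds on other cores in the series, and they do not explain why pyridin-4-yl gives the higher number.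

The compounds shown leave open what a pyridin-2-yl group, or a pyridine ring carrying an amine, would give at this place. They also leave open whether the same step would appear in other cell lines.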